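The source may hold more compounds than are shown below. What is called first, only, known or untested is meant among the compounds shown, and "the series" means these compounds.

Working notes on the series. The read-out throughout is an ADME assay on HCT-116 cells (Homo sapiens) for cytotoxicity, read by CellTiter-Glo, with a stated time of 72 h; on this read-out lower numbers stand for stronger inhibition and higher numbers for weaker inhibition. Compound 1, with the structure `Cc1nc(Cl)sc1S(=O)(=O)N1CCC(N2CCC(C)CC2)CC1`, gives > 10000 nM in this assay, and this is a limit of the assay rather than a number (the limit of > 10000 nM in this assay, at which 1 of the 2 values shown sits). Compound 2, with the structure `CC1CCN(C2CCN(S(=O)(=O)c3cccc(C(F)(F)F)c3)CC2)CC1`, gives > 5000 nM in this assay, again a limit rather than a number (the limit of > 5000 nM in this assay, at which 1 of the 2 values shown sits). So compound 1 stands at a limit, and the only other value shown is also a limit; no step between measured compounds is available in this set.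

Compound 3, with the structure `CC1CCN(C2CCN(S(=O)(=O)c3cccnc3)CC2)CC1`, is not yet measured. Its difference from compound 1 is pyridin-3-yl in place of 2-chloro-4-methyl-1,3-thiazol-5-yl on a sulfonyl sulfur. Neither measured value gives a number to move from, so no step beyond the scatter is expected in this assay. The step from compound 1 to compound 3 is expected to be a step that the limit leaves unreadable from compound 1 to compound 3. Compound 3 is expected to give 15000 nM, between 5000 nM and 50000 nM, most probably reported again as a limit.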

Compound 3, half-maximal inhibitory concentration: > 10000 nM
Compound 3: a limit, no number; the forecaster's own chance of this, stated with the estimate: 80%; the middle value does not contradict the limit.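

Within the data shown here, compound 1 and compound 3 both stand at a limit rather than a number, so no step between them can be read. The compounds shown leave open whether any change on the sulfonyl sulfur gives a measurable value in this assay.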